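Swapping the amide nitrogen substituent: compound 2 to compound 3

This account rests on a few compounds, and the source may have more. Where it says the series, first, only, none or still open, it means among the compounds named here.

Measured so far:
compound 1, `COc1cc(-c2nnc(SCC(=O)c3ccc(C(F)(F)F)cc3)n2N)cc(OC)c1OC`: > 100000 nM (a limit of the assay)
compound 2, `COc1cc(-c2nnc(SCC(=O)Nc3ccccc3)n2N)cc(OC)c1OC`: 37900 nM

Among the measured compounds shown here, in a functional assay on PC-3 cells (Homo sapiens) for antiproliferative activity, read by MTT assay, with a stated time of 48 h (on this read-out lower numbers stand for stronger inhibition and higher numbers for weaker inhibition), compound 2 gives 37900 nM, the only number among the two values shown. Compound 1 sits at > 100000 nM, which is a limit of the assay. For the measured compounds named here, the one measured step, an at least 2.6-fold lower number from compound 1 to compound 2 (0.42 log units; beyond the scatter), changes the group on the carbonyl carbon, and its starting point is the limit of > 100000 nM in this assay, at which 1 of the 2 values shown sits. Compound 3, `COc1ccc(CNC(=O)CSc2nnc(-c3cc(OC)c(OC)c(OC)c3)n2N)cc1OC`, differs from compound 2 by 3,4-dimethoxybenzyl in place of phenyl on an amide-type nitrogen. Going by the values given here, no measured step touches the group on the amide nitrogen, so a small step is expected. Compound 3 is estimated at 25000 nM, with a range of 8000 nM to 80000 nM, an expected 1.5-fold lower number from compound 2 to compound 3 (0.18 log units; within the scatter) that may lie within the scatter.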

Compound 3, half-maximal inhibitory concentration: > 100000 nM
Compound 3: no number, only a limit; the forecaster's own chance of this, stated with the estimate: 15%; middle value at least 4.0-fold (0.60 log units) away from the limit.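

With the amide kept, the group on its nitrogen alone moves the result in this assay, by an at least 2.6-fold higher number from compound 2 to compound 3 (0.42 log units; beyond the scatter) on going to 3,4-dimethoxybenzyl. As far as these compounds go, compound 3 gives > 100000 nM as a limit of the assay and not a number, so the true size of this step stays unknown. Among the compounds shown here, only phenyl on this nitrogen has given a number so far, and most of the set now reads as limits: the limit of > 100000 nM in this assay, at which 2 of the 3 values shown sit. From the compounds shown here alone, whether plain benzyl, without the methoxy groups, or a methyl on this nitrogen would give a number stays open. So does the effect of a chlorine or a methoxy on the phenyl of compound 2.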